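Removing the methylsulfonyl group from the phenyl of compound 2

The source may hold more compounds than are shown below. What is called first, only, known or untested is meant among the compounds shown, and "the series" means these compounds.

Compound 2 `COc1cc(OCc2csc(-c3ccc(S(C)(=O)=O)cc3)n2)c2cc(-c3cn4nc(OC)sc4n3)oc2c1` stands lowest of the two numbers in a functional assay on HEK293 cells for antagonist activity at proteinase-activated receptor 4 (Homo sapiens), read by FLIPR and calcium flux, with a stated time of 30 min (on this read-out higher numbers stand for weaker inhibition and lower numbers for stronger inhibition), where compound 2 gives 0.8 nM. Within the data shown here, its nearest neighbour is compound 1 `COc1cc(OCc2csc(-c3ccc(C(C)(C)O)cc3)n2)c2cc(-c3cn4nc(OC)sc4n3)oc2c1`, which in this assay gives 2.4 nM; the single measured step, a 3.0-fold lower number from compound 1 to compound 2 (0.48 log units; beyond the scatter), was modest and exchanges one group for another at the same aromatic carbon.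

Compound 3 `COc1cc(OCc2csc(-c3ccccc3)n2)c2cc(-c3cn4nc(OC)sc4n3)oc2c1` is not yet measured. It differs from compound 2 by hydrogen in place of methylsulfonyl on an aromatic carbon, so the six-membered aromatic ring of carbon only is left bare at that carbon. The measured step bears on this only indirectly: it shows that two different groups at this carbon both give low numbers in this assay, with the methylsulfonyl the lower of the two, but nothing measured shows the ring without a group. An upward step of modest size is therefore expected, since compound 1 with a different group there already sits at 2.4 nM; the step of a 3.8-fold higher number from compound 2 to compound 3 (0.57 log units; beyond the scatter) is the expected one. Compound 3 is expected to give 3 nM in this assay, within 1 nM to 12 nM.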

Compound 3, half-maximal inhibitory concentration: 0.3 nM
The estimate for compound 3 lay 10-fold (1.00 log units) above the measured number, outside the stated range (below it).
By their numbers in this assay, from the lowest: compound 3; then compound 2; then compound 1.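

In this assay the unsubstituted phenyl gives the lowest number of the three, so a low number does not depend on a group at this aromatic carbon: removing the methylsulfonyl gives a 2.7-fold lower number from compound 2 to compound 3 (0.43 log units; beyond the scatter) and, in the comparison with the tertiary alcohol, replacing 1-hydroxy-1-methylethyl with hydrogen gives an 8.0-fold lower number from compound 1 to compound 3 (0.90 log units; beyond the scatter) in the same direction. The earlier step only ranked two groups against each other, whereas hydrogen now provides a reference against which both groups carry higher numbers, with 1-hydroxy-1-methylethyl higher than methylsulfonyl. No measurement at hand explains the order of the three compounds.

Still open, as far as these compounds go, is whether any group at this carbon can give a lower number than hydrogen, and whether the upward shift seen with these two groups extends to others, such as fluorine, an amine or a carboxylic acid. The compounds shown also leave open whether the same order of hydrogen, methylsulfonyl and 1-hydroxy-1-methylethyl would hold on a different core, since all three compounds share one.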